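Cutting back the hydroxycarbamoyl chain of compound 2

A few compounds are considered here, and "the series" means these few. Any claim that something is new, unique, unknown or untested is made for them only; others in the source may bear on it.

In a functional assay on SK-HEP1 cells (Homo sapiens) for inhibition, read by MTT assay, with a stated time of 72 h (on this read-out higher numbers stand for weaker inhibition and lower numbers for stronger inhibition), compound 1 `Nc1ncnc2c1c(-c1cnc3[nH]ccc3c1)nn2CCCCCCCCC(=O)NO` gives 11200 nM, compound 2 `Nc1nc2cc(-c3nn(CCCCCCCCCC(=O)NO)c4ncnc(N)c34)ccc2o1` gives 14100 nM and compound 3 `Nc1ncnc2c1c(-c1cnc3[nH]ccc3c1)nn2CCCCCCCCCC(=O)NO` gives 23500 nM. Compound 2 thus lies within the scatter of both other compounds. Exchanging the aromatic group on the shared core gives a 1.7-fold higher number from compound 2 to compound 3 (0.22 log units; within the scatter), so that exchange does not separate the two compounds.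

Compound 4 `Nc1nc2cc(-c3nn(CCCCC(=O)NO)c4ncnc(N)c34)ccc2o1` keeps the core and aromatic group of compound 2 and shortens the chain: hydroxycarbamoyl in place of 5-(hydroxycarbamoyl)pentyl on a saturated chain carbon, four bonds along the chain from an aromatic nitrogen.

Among the measured compounds shown here, only one measured step touches chain length, and it was modest: a 2.1-fold higher number from compound 1 to compound 3 (0.32 log units; beyond the scatter). Read in reverse, that step points to a lower number on shortening. However, it was measured with another aromatic group, and the cut in compound 4 is much larger. The data do not show how far the trend runs, so a modest fall is expected, with real room in either direction. The expected change is a 1.6-fold lower number from compound 2 to compound 4 (0.19 log units; within the scatter). Compound 4 is estimated at 9000 nM, with an expected range of 2500 nM to 35000 nM.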

Compound 4, half-maximal inhibitory concentration: 6400 nM
Estimate against measurement, compound 4: 1.4-fold (0.15 log units) above; low and high end bracket the measured number.
By their numbers in this assay, from the lowest: compounds 4, 1, 2 and 3 (each within the scatter of the next, the first and the last beyond it).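

In this assay, the much larger cut at this position, hydroxycarbamoyl in place of 5-(hydroxycarbamoyl)pentyl, gives a 2.2-fold lower number from compound 2 to compound 4 (0.34 log units; beyond the scatter), so the shorter chain now separates two compounds beyond the scatter while the aromatic group of compound 2 stays in place. Shortening thus goes with a lower number on both aromatic groups, since the earlier step with the other group ran the same way, as a 2.1-fold higher number from compound 1 to compound 3 (0.32 log units; beyond the scatter), and the far larger cut moves the number by about the same amount as that smaller change. Nothing available explains why the number falls with this cut.

The compounds shown leave open how the number behaves at chain lengths between those of compound 2 and compound 4, and whether the same short chain lowers the number on the aromatic group of compound 1. They also leave open whether the hydroxycarbamoyl end itself matters, which a carboxylic acid or an amine at the chain end would test.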